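The source may report more compounds than this note shows. Statements on the series, on what has been measured and on what is new or still open speak of the compounds shown alone.

Measured so far in a physicochemical assay for lipophilicity, read by HPLC, at pH 7.5; a lower number here means a more polar compound, a higher number a more lipophilic compound:
Compound 1 `CC[C@@H](Nc1c(C#N)c(-c2ccc(-c3ccc(F)cc3)cc2)nc2cnccc12)C(N)=O` gives 2.7.
Compound 2 `CN(CC(N)=O)c1c(C#N)c(-c2ccc(Br)cc2)nc2cnccc12` gives 2.1.
Compound 3 `CC(C)(CC(N)=O)c1c(C#N)c(-c2ccc(Br)cc2)nc2cnccc12` gives 2.1.

Of these three numbers, compound 1 stands highest: compound 2 and compound 3 both lie lower by a margin that is beyond the scatter, while compound 2 and compound 3 sit within the scatter of each other. Going by the values given here, the one step measured between compounds that differ in one place, no change at the digits printed from compound 2 to compound 3 (within the scatter), concerns a different part of the shared core and does not touch the aryl group that changes here.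

Compound 4 `CC[C@@H](Nc1c(C#N)c(-c2ccc(-c3cccc(OC)c3)cc2)nc2cnccc12)C(N)=O` differs from compound 1 in one place: 3-methoxyphenyl in place of 4-fluorophenyl on an aromatic carbon. Among the compounds with values here, no measured step bears on this change, so the expectation rests on the structural change alone. In this assay compound 4 is expected to show a step of a number 0.20 log units lower from compound 1 to compound 4 (within the scatter) from compound 1, a small decrease that may not exceed the scatter. Compound 4 is therefore estimated at 2.5, with a range from 2.1 to 2.9.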

Compound 4, distribution coefficient: 2.7
Beside the measured number, compound 4's estimate is 0.20 log units below it; the measured number falls inside the stated range.
By their numbers in this assay, from the lowest: compounds 2 and 3 (each within the scatter of the next); then compounds 1 and 4 (each within the scatter of the next).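

In this assay, 3-methoxyphenyl in place of 4-fluorophenyl, on an aromatic carbon para to a large group, gives no change at the digits printed from compound 1 to compound 4 (within the scatter). Going by these compounds alone, this is the first measured change at this position, and it shows that the number can hold when the group here gains a heavy atom and a hydrogen-bond acceptor and loses its fluorine. No measurement available here explains why the number holds.

This single pair changes both the substituent and its place on the ring, so it does not show which of the two, if either, matters alone. It also leaves open whether a carboxylic acid or an amine on this ring, or replacing the ring with a longer chain, would move the number.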